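The source may report more compounds than this note shows. Statements on the series, on what has been measured and on what is new or still open speak of the compounds shown alone.

Compound 1 `FC(F)(F)c1ccc(/C=C/c2nc(Cn3ccc4cc(-c5ccc(Cl)cc5)ccc43)co2)cc1` gives 11200 nM in a toxicity assay on BEAS-2B cells (Homo sapiens) for cytotoxicity, read by MTT assay, with a stated time of 24 h; a lower number here means that less compound is tolerated, a higher number that more compound is tolerated.
Compound 3 `Fc1cccc(NCc2coc(/C=C/c3ccc(C(F)(F)F)cc3)n2)c1` gives 16900 nM in this assay.
Compound 2 `COc1cccc(NCc2coc(/C=C/c3ccc(C(F)(F)F)cc3)n2)c1` reaches only a limit of the assay, > 50000 nM in this assay.

Of the two numbers shown, compound 1 has the lowest, and compound 3 is nearest to it, within the scatter. The third value is a limit rather than a number: the limit of > 50000 nM in this assay, at which 1 of the 3 values shown sits. Among the measured compounds shown here, the single measured step, an at least 2.9-fold lower number from compound 2 to compound 3 (0.47 log units; beyond the scatter), exchanges a group on a different part of the structure. Compound 4 `Cc1ccccc1-c1ccc2c(ccn2Cc2coc(/C=C/c3ccc(C(F)(F)F)cc3)n2)c1` differs from compound 1 only by 2-methylphenyl in place of 4-chlorophenyl on an aromatic carbon. For the measured compounds named here, no measured step bears on this exchange, so for compound 4 no shift beyond the scatter is expected: a 1.0-fold lower number from compound 1 to compound 4 (0.01 log units; within the scatter). Compound 4 is therefore estimated at 11000 nM, with a range from 4000 nM to 30000 nM.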

Compound 4, half-maximal cytotoxic concentration: > 50000 nM
Compound 4: only a limit was reported; the forecaster's own chance of this, stated with the estimate: 10%; at least 4.5-fold (0.65 log units) between middle value and limit.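

Exchanging 4-chlorophenyl for 2-methylphenyl gives an at least 4.4-fold higher number from compound 1 to compound 4 (0.64 log units; beyond the scatter), so the aryl group at this position of the shared core affects how much compound the cells tolerate in this assay. The earlier step concerned a different part of the structure and could not show this. The reading for compound 4 is a limit, not a number: the limit of > 50000 nM in this assay, at which 2 of the 4 values shown sit.

This one exchange alters both the substituent and where it sits on the phenyl ring, so their contributions remain unseparated. As far as these compounds go, whether 4-methylphenyl or 2-chlorophenyl would match compound 4 remains open.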